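A few compounds are considered here, and "the series" means these few. Any claim that something is new, unique, unknown or untested is made for them only; others in the source may bear on it.

Measured compounds:
compound 1 `CC(C)Cc1ccc(C(C)c2n[nH]c(=S)n2N)cc1` gives 16200 nM in a functional assay on Mahlavu cells (Homo sapiens) for inhibition, read by sulforhodamine B assay, with a stated time of 72 h; on this read-out lower numbers stand for stronger inhibition and higher numbers for weaker inhibition
compound 2 `CC(c1ccc(-c2ccccc2)c(F)c1)c1nnc2n1N=C(c1ccc(Cl)cc1Cl)CS2` gives 6600 nM in this assay

Of these two numbers compound 2 has the lower one, and the gap to compound 1 lies beyond the scatter. Compound 3 `COc1ccc(C2=Nn3c(nnc3C(C)c3ccc(-c4ccccc4)c(F)c3)SC2)cc1` has not yet been measured. It differs from compound 2 in one place: 4-methoxyphenyl in place of 2,4-dichlorophenyl on a carbon with a double bond to nitrogen. Within the data shown here, no measured pair shows this change, so its size in this assay is unknown. Among the measured compounds shown here, compound 3 is expected to be somewhat weaker, a step of a 1.5-fold higher number from compound 2 to compound 3 (0.18 log units; within the scatter), yet this expectation rests on no measured pair. Compound 3 is estimated at 10000 nM, with a range from 4000 nM to 30000 nM.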

Compound 3, half-maximal inhibitory concentration: 5800 nM
Beside the measured number, compound 3's estimate is 1.7-fold (0.24 log units) above it; measured number inside the range.
By their numbers in this assay, from the lowest: compounds 3 and 2 (each within the scatter of the next); then compound 1.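

In this assay, 4-methoxyphenyl in place of 2,4-dichlorophenyl on the carbon with a double bond to nitrogen gives a 1.1-fold lower number from compound 2 to compound 3 (0.06 log units; within the scatter) as its step, so the two compounds cannot be told apart at this position. The two chlorine atoms are therefore not required to keep the number at this level, and neither group stands out here. Nothing available explains this result. From the compounds shown here alone, whether a pyridine ring or a simple methyl group at this position would change the number remains open. So does the effect of an amine or a carboxylic acid on the phenyl ring.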